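The source may hold more compounds than are shown below. What is called first, only, known or untested is meant among the compounds shown, and "the series" means these compounds.

In a functional assay on NCI-H460 cells (Homo sapiens) for cytotoxicity, read by MTT assay, with a stated time of 72 h (on this read-out higher numbers stand for weaker inhibition and lower numbers for stronger inhibition), the measured compounds:
compound 1 `CCCCCCCCNC1=CC(=O)C=C(C(C)(C)C)C1=O` gives 20000 nM
compound 2 `CC(C)(C)C1=CC(=O)C=C(NCc2ccccc2)C1=O` gives 14000 nM
compound 3 `CC(C)(C)C1=CC(=O)C=CC1=O` gives > 100000 nM as a limit of the assay

Compound 3 is known only through the limit of > 100000 nM in this assay, at which 1 of the 3 values shown sits, and carries no number. Ethylamino in place of hydrogen on a double-bonded ring carbon leads to compound 4 `CCNC1=CC(=O)C=C(C(C)(C)C)C1=O` (ethylamino in place of hydrogen on a double-bonded ring carbon). Among the compounds with values here, the one measured step that bears on this change lies among the amines, a 1.4-fold lower number from compound 1 to compound 2 (0.15 log units; within the scatter), so exchanging the group on the amine nitrogen moved little there. Compound 4, also an amine, is therefore expected to sit close to compound 1 at 20000 nM and compound 2 at 14000 nM in this assay. A clear step to a lower number is expected, an at least 4.0-fold lower number from compound 3 to compound 4 (0.60 log units; beyond the scatter), beyond the scatter. For compound 4 the estimate is 25000 nM, with an expected range of 10000 nM to 65000 nM.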

Compound 4, half-maximal inhibitory concentration: 13000 nM
The estimate for compound 4 lay 1.9-fold (0.28 log units) above the measured number, and the stated range covers the measured number.
By their numbers in this assay, from the lowest: compounds 4, 2 and 1 (each within the scatter of the next). At a limit, above all of these: compound 3.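

Ethylamino in place of hydrogen on the double-bonded ring carbon gives an at least 7.6-fold lower number from compound 3 to compound 4 (0.88 log units; beyond the scatter) and is the first change in the series to move the number beyond the scatter. Among the amines, the group on the nitrogen matters little, with a 1.1-fold lower number from compound 2 to compound 4 (0.03 log units; within the scatter) and a 1.5-fold lower number from compound 1 to compound 4 (0.19 log units; within the scatter) both within the scatter. The size of the first step remains bounded only, since compound 3 stands at a limit of the assay: the limit of > 100000 nM in this assay, at which 1 of the 4 values shown sits.

From the compounds shown here alone, whether the nitrogen itself is required remains open. A methoxy group, a plain ethyl chain or an unsubstituted amine on this ring carbon would test that.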